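Adding a Methyl Group in Two Different Places

The source may report more compounds than this note shows. Statements on the series, on what has been measured and on what is new or still open speak of the compounds shown alone.

Compound 1 `COc1ccc(-c2cc3c(cn2)[nH]c(=O)n3-c2cc(OC)c(OC)c(OC)c2)cc1` was tested in a functional assay on A2780 cells (Homo sapiens) for antiproliferative activity, read by MTT assay, with a stated time of 48 h (on this read-out lower numbers stand for stronger inhibition and higher numbers for weaker inhibition), where compound 1 gives 930 nM. Compound 2 `CCOc1ccc(-c2cc3c(cn2)[nH]c(=O)n3-c2cc(OC)c(OC)c(OC)c2)cc1` differs from compound 1 in one place, (methyl in place of hydrogen on a saturated chain carbon bound to an oxygen on an aromatic ring). That single change made a 3.2-fold higher number from compound 1 to compound 2 (0.51 log units; beyond the scatter). Compound 3 `COc1ccc(-c2cc3c(cn2)n(C)c(=O)n3-c2cc(OC)c(OC)c(OC)c2)cc1O` carries a different core from compound 1; the difference between the two cores is not broken down here. In this assay compound 3 gives 1720 nM, and in this assay compound 2 gives 2980 nM.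

Compound 4 `CCn1c(=O)n(-c2cc(OC)c(OC)c(OC)c2)c2cc(-c3ccc(OC)c(O)c3)ncc21` has not yet been measured. It differs from compound 3 by methyl in place of hydrogen on a saturated chain carbon bound to an aromatic nitrogen. Among the compounds with values here, this is the same kind of change as the one from compound 1 to compound 2, but not the same: there the saturated chain carbon is bound to an oxygen on an aromatic ring, here it is bound to an aromatic nitrogen. Compound 4 is expected to show a 2.0-fold higher number from compound 3 to compound 4 (0.31 log units; beyond the scatter) in this assay, an expectation resting on the earlier step of a 3.2-fold higher number from compound 1 to compound 2 (0.51 log units; beyond the scatter) for the same kind of change; the place is not the same, so the expected step is held more loosely. The estimate for compound 4 is 3500 nM, with a range from 1500 nM to 9000 nM.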

Compound 4, half-maximal inhibitory concentration: > 20000 nM
Compound 4: only a limit was reported; the forecaster's own chance of this, stated with the estimate: 5%; middle value at least 5.7-fold (0.75 log units) away from the limit.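

In this assay, putting a methyl in place of a hydrogen raised the number in both places, and the new case gave an at least 11-fold higher number from compound 3 to compound 4 (1.06 log units; beyond the scatter), so the size of the step did not carry over from one core to the other: the same change on two cores in this assay, a 3.2-fold higher number (0.51 log units; beyond the scatter) from compound 1 to compound 2 and an at least 11-fold higher number (1.06 log units; beyond the scatter) from compound 3 to compound 4, at least 3.6-fold (0.55 log units) apart, beyond the scatter of two such steps The value of compound 4, > 20000 nM, is a limit and not a number: the limit of > 20000 nM in this assay, at which 1 of the 4 values shown sits. The two steps sit at different places, one on a saturated chain carbon bound to an oxygen on an aromatic ring and the other on a saturated chain carbon bound to an aromatic nitrogen, and their cores differ as well, so this pair cannot separate place from core and sets no rule for the series.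

As far as these compounds go, whether a longer chain such as propyl, or a chain ending in an amine, on the aromatic nitrogen would give a readable number remains open. Also open, from the compounds shown here alone, is how large the step on the oxygen-bound chain would be on the core of compound 3.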